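Swapping Chloro for Trifluoromethyl in a Series

The compounds below may be only part of what the source reports. "The series", "measured", "known", "first", "only" and "open" are said of these compounds alone.

Compound 1 `CC(C)(C)Cc1csc(N)c1C(=O)c1cccc(Cl)c1` and compound 2 `CC(C)(C)Cc1csc(N)c1C(=O)c1cccc(C(F)(F)F)c1` share one core; in an assay on CHO cells for displacement of a labelled ligand from adenosine receptor A1 (Homo sapiens), read by scintillation counting, tested at 10 uM (on this read-out higher numbers stand for more inhibition at the one concentration tested (going by the name of the read-out) and lower numbers for less inhibition), compound 1 gives 2%, and compound 2 gives 1%. The change between them, (trifluoromethyl in place of chloro on an aromatic carbon), made a step of a number 1 percentage points lower from compound 1 to compound 2 (within the scatter). Compound 3 `CC(C)(C)Cc1c(-c2ccccc2)sc(N)c1C(=O)c1cccc(Cl)c1` differs from compound 1 by phenyl in place of hydrogen on an aromatic carbon; in this assay compound 3 gives 2%, a step of no change at the digits printed from compound 1 to compound 3 (within the scatter). Compound 4 `CC(C)(C)Cc1c(-c2ccccc2)sc(N)c1C(=O)c1cccc(C(F)(F)F)c1` differs from compound 3 by trifluoromethyl in place of chloro on an aromatic carbon, the same change that was made from compound 1 to compound 2, at a place described in the same words. For compound 4 the expected step is no change at the digits printed from compound 3 to compound 4 (within the scatter), which rests on the step of a number 1 percentage points lower from compound 1 to compound 2 (within the scatter) seen with this same change. Compound 4 is therefore estimated at 2% in this assay, between -6% and 10%.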

Compound 4, a percentage reported as inhibition, at one concentration (the size of the read-out at that concentration, not a potency): 1%
Compound 4: middle estimate off by 1 percentage points, on the high side; measured number inside the range.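

Trifluoromethyl in place of chloro on the phenyl-bearing core gave a number 1 percentage points lower from compound 3 to compound 4 (within the scatter), which matches what the same change did on the core of compound 1: the same change on two cores in this assay, a number 1 percentage points lower (within the scatter) from compound 1 to compound 2 and a number 1 percentage points lower (within the scatter) from compound 3 to compound 4, 0 percentage points apart, within the scatter of two such steps

Phenyl in place of hydrogen likewise gave no change at the digits printed from compound 2 to compound 4 (within the scatter), which matches its earlier step: the same change on two cores in this assay, no change at the digits printed (within the scatter) from compound 1 to compound 3 and no change at the digits printed (within the scatter) from compound 2 to compound 4, 0 percentage points apart, within the scatter of two such steps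

Within the data shown here, both changes therefore read alike on the two cores, but since every step lies within the scatter, this agreement shows only that neither change moved the number measurably here, not that a measurable effect carries from one core to another.

Going by these compounds, whether an amine or a carboxylic acid in place of the chloro, or a longer chain in place of the phenyl, would shift the reading in this assay remains open.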